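Removing the nitro group from a dithiocarbamate benzamide

The compounds below may be only part of what the source reports. "The series", "measured", "known", "first", "only" and "open" are said of these compounds alone.

Measured so far:
compound 1 `Nc1ccccc1NC(=O)c1ccc(CSC(=S)N2CCc3cc([N+](=O)[O-])ccc32)cc1` — 29.5%
compound 2 `Nc1ccccc1NC(=O)c1ccc(CSC(=S)N2CCN(Cc3ccncc3)CC2)cc1` — 89.5%

The two measured compounds share a benzamide core bearing a dithiocarbamate and differ in the amine attached to it. In a functional assay on A-375 cells (Homo sapiens) for antiproliferative activity, read by CCK-8 assay, with a stated time of 72 h, tested at 8 uM (a lower number here means a weaker effect, a higher number a stronger effect of the compound at the concentration tested), compound 1 gives 29.5%, the lower of the two numbers; compound 2 gives 89.5%, a difference well beyond the scatter. The unmeasured compound 3 `Nc1ccccc1NC(=O)c1ccc(CSC(=S)N2CCc3ccccc32)cc1` keeps the fused ring system of compound 1 and differs from it in one place: hydrogen in place of nitro on an aromatic carbon. Among the measured compounds shown here, no measured pair shows what this change does to the read-out, so the direction cannot be read from the data. The low value of compound 1, 29.5%, leaves room upward, and a modest rise is expected, though a step within the scatter is equally plausible. The estimated step of a number 10.5 percentage points higher from compound 1 to compound 3 (beyond the scatter) is expected to be small. Compound 3 is thus expected to give about 40%, within 15% to 70%.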

Compound 3, a percentage reported as inhibition, at one concentration (the size of the read-out at that concentration, not a potency): 85.4%
Estimate against measurement, compound 3: 45.4 percentage points below; measured number outside the range, above it.
By their numbers in this assay, from the lowest: compound 1; then compounds 3 and 2 (each within the scatter of the next).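

Hydrogen in place of nitro on an aromatic carbon of the fused system of two rings gives a number 55.9 percentage points higher from compound 1 to compound 3 (beyond the scatter) in this assay, so a single substituent at this position governs much of the read-out. The low number of compound 1 therefore goes with the nitro group rather than with the fused ring system itself: compound 3 keeps that system and gives 85.4%. Nothing available explains why removing the nitro group has a step of this size.

The compounds shown leave open whether the nitro group is unusual here, or whether an amine, a fluorine or a methoxy group on the same aromatic carbon would also lower the read-out. They also leave open whether a nitro group on another aromatic carbon of that ring would do the same.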